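Cytotoxicity on Vero cells across the alkynyl series

The source may hold more compounds than are shown below. What is called first, only, known or untested is meant among the compounds shown, and "the series" means these compounds.

Measured so far:
compound 1 `CCCCC#Cc1c[nH]c(=O)[nH]c1=O`, 253000 nM
compound 2 `O=c1[nH]cc(C#CC2CCCCC2)c(=O)[nH]1`, 247000 nM

In an ADME assay on Vero cells (Chlorocebus sabaeus) for cytotoxicity, read by MTT assay (a lower number here means that less compound is tolerated, a higher number that more compound is tolerated), compound 1 gives 253000 nM and compound 2 gives 247000 nM; the two numbers lie within the scatter of each other, so neither can be called better tolerated. Compound 1 carries the higher of the two numbers by a margin that means nothing.

Compound 3 `CCC#Cc1c[nH]c(=O)[nH]c1=O` has not yet been run in this assay. It differs from compound 1 by hydrogen in place of ethyl on a saturated chain carbon, two bonds along the chain from a triple-bonded carbon. Among the measured compounds shown here, no step between measured compounds of this kind is available; what is known is that compound 1 and compound 2, with different groups on the alkyne, sit at the same level. The expectation for the step from compound 1 to compound 3 is therefore a change of a 1.1-fold higher number from compound 1 to compound 3 (0.03 log units; within the scatter), nothing beyond the scatter, in no firm direction. Compound 3 is estimated at 270000 nM, with a range of 120000 nM to 600000 nM.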

Compound 3, half-maximal cytotoxic concentration: 263000 nM
Beside the measured number, compound 3's estimate is 1.0-fold (0.01 log units) above it; measured number inside the range.
By their numbers in this assay, from the lowest: compounds 2, 1 and 3 (each within the scatter of the next).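

Hydrogen in place of ethyl on a saturated chain carbon, two bonds along the chain from a triple-bonded carbon, gives the first step readable at this position, and in this assay it reads a 1.0-fold higher number from compound 1 to compound 3 (0.02 log units; within the scatter) and so gives no sign that ethyl matters here. Within this single pair, the shorter chain of compound 3 and the longer chain of compound 1 cannot be told apart in this assay, which a comparison of compound 1 with compound 2 could not show for a change at one place on the chain. No supporting data bear on why the two stay at one level. As far as these compounds go, whether a longer chain such as octyl would hold that level remains open. So does the outcome for an amine or a carboxylic acid in place of the ethyl.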